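A few compounds are considered here, and "the series" means these few. Any claim that something is new, unique, unknown or untested is made for them only; others in the source may bear on it.

Measured so far in a functional assay on A549 cells (Homo sapiens) for inhibition, read by sulforhodamine B assay, with a stated time of 72 h; a lower number here means a stronger inhibitor, a higher number a weaker inhibitor:

compound 1 `CCN(Cc1ccc(OC)cc1)Cc1c(O)ccc2c(=O)cc(C)oc12`: 38.7 ug/mL
compound 2 `COc1ccc(CN(Cc2ccc([N+](=O)[O-])cc2)Cc2c(O)ccc3c(=O)cc(C)oc23)cc1`: 24.5 ug/mL

Among the measured compounds shown here, compound 2 and compound 1 are the only two compounds with numbers, and the gap between them, a 1.6-fold lower number from compound 1 to compound 2 (0.20 log units; within the scatter), lies within the scatter, so compound 2 is not separated from compound 1.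

Compound 3 `COc1ccc(CN(Cc2ccc3ccccc3c2)Cc2c(O)ccc3c(=O)cc(C)oc23)cc1` differs from compound 2 by naphthalen-2-yl in place of 4-nitrophenyl on a saturated chain carbon bound to an amine nitrogen. For the measured compounds named here, the one measured step at this place, a 1.6-fold lower number from compound 1 to compound 2 (0.20 log units; within the scatter), was within the scatter; no measured step covers the entry of naphthalen-2-yl, so nothing in the data points to a change in either direction. The expectation for compound 3 is therefore a step of a 1.1-fold lower number from compound 2 to compound 3 (0.05 log units; within the scatter) in this assay , not beyond the scatter. Compound 3 is estimated at 22 ug/mL, with a range from 9 ug/mL to 55 ug/mL.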

Compound 3, half-maximal inhibitory concentration: 6.01 ug/mL
The estimate for compound 3 lay 3.7-fold (0.56 log units) above the measured number; measured number below the stated range.
By their numbers in this assay, from the lowest: compound 3; then compounds 2 and 1 (each within the scatter of the next).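

In this assay the saturated chain carbon bound to the amine nitrogen now gives steps beyond the scatter, with a 4.1-fold lower number from compound 2 to compound 3 (0.61 log units; beyond the scatter) for naphthalen-2-yl in place of 4-nitrophenyl and a 6.4-fold lower number from compound 1 to compound 3 (0.81 log units; beyond the scatter) for naphthalen-2-yl in place of methyl. Methyl and 4-nitrophenyl were not separated at this place, so among the three groups shown only naphthalen-2-yl stands apart, and the position is not indifferent to the group it carries. Nothing available bears on the reason for this step.

The change from 4-nitrophenyl to naphthalen-2-yl both removes the nitro group and adds a second aromatic ring, and the compounds shown do not separate these two differences. Plain phenyl at this place would help to separate them, while 1-naphthyl would test whether the point of attachment on the naphthalene matters.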